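This account rests on a few compounds, and the source may have more. Where it says the series, first, only, none or still open, it means among the compounds named here.

Measured compounds:
Compound 1 `COc1cc(-c2csc(NC(=O)c3ccccc3)n2)cc(OC)c1OC`: in a functional assay on MDA-MB-231 cells (Homo sapiens), read by microscopy and transwell migration, with a stated time of 24 h (on this read-out lower numbers stand for stronger inhibition and higher numbers for weaker inhibition), compound 1 gives > 50000 nM, which is a limit of the assay rather than a number.
Compound 2 `Cc1ccc(-c2cnc(NC(=O)c3ccccc3)s2)cc1`: in this assay compound 2 gives 308 nM.
Compound 3 `COc1cc(-c2csc(N(C)C(=O)c3ccccc3)n2)cc(OC)c1OC`: in this assay compound 3 gives 10000 nM.

The change from compound 1 to compound 3 is methyl in place of hydrogen on an amide-type nitrogen. It gave an at least 5.0-fold lower number from compound 1 to compound 3 (0.69 log units; beyond the scatter), but the starting value is only a limit (the limit of > 50000 nM in this assay, at which 1 of the 3 values shown sits), so the true size of that step is not pinned down. Compound 2 holds the lowest of the two numbers; how its core differs from the core of compound 1 is not broken down here.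

Compound 4 `Cc1ccc(-c2cnc(N(C)C(=O)c3ccccc3)s2)cc1` awaits measurement. It differs from compound 2 by methyl in place of hydrogen on an amide-type nitrogen, the same change made twice among the compounds shown, at a place described in the same words. Compound 2 already sits at 308 nM, and the size of the earlier step is not pinned down. A smaller move is expected here, about a 1.5-fold lower number from compound 2 to compound 4 (0.19 log units; within the scatter). Compound 4 is estimated at 200 nM in this assay, most likely between 50 nM and 1000 nM.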

Compound 4, half-maximal inhibitory concentration: 1090 nM
For compound 4 the middle estimate is 5.5-fold (0.74 log units) below the measured one, outside the stated range (above it).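

In this assay, methyl in place of hydrogen on an amide-type nitrogen gives a 3.5-fold higher number from compound 2 to compound 4 (0.55 log units; beyond the scatter), so on this core the change weakens inhibition. The change does not carry over from one core to the other with the same direction or size: the same change on two cores in this assay, an at least 5.0-fold lower number (0.69 log units; beyond the scatter) from compound 1 to compound 3 and a 3.5-fold higher number (0.55 log units; beyond the scatter) from compound 2 to compound 4, at least 17-fold (1.24 log units) apart, beyond the scatter of two such steps For compound 1 the starting value is only a limit, so the size of the step on its core remains unfixed, and two pairs say nothing about further cores: the limit of > 50000 nM in this assay, at which 1 of the 4 values shown sits.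

From the compounds shown here alone, compound 1 and compound 2 differ in more than one place, so it remains open which difference between the cores goes with the reversal. Also open, going by these compounds, is how an ethyl group or a longer chain in place of the methyl would read on either core.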